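A few compounds are considered here, and "the series" means these few. Any claim that something is new, unique, unknown or untested is made for them only; others in the source may bear on it.

Compound 3 `CCCNC(=O)c1cc(Oc2ccc(NC(=O)c3cc4cccnc4n(-c4ccc(Cl)cc4)c3=O)cc2)ccn1` gives 390 nM in a functional assay on HT-29 cells (Homo sapiens) for antiproliferative activity, read by MTT assay, with a stated time of 72 h (on this read-out higher numbers stand for weaker inhibition and lower numbers for stronger inhibition), the second highest of the three numbers measured. Compound 1 `CCNC(=O)c1cc(Oc2ccc(NC(=O)c3cc4cccnc4n(-c4ccc(Cl)cc4)c3=O)cc2)ccn1` gives 330 nM in this assay. The step of a 1.2-fold higher number from compound 1 to compound 3 (0.07 log units; within the scatter), so these two compounds stand together. Compound 2 `CCNC(=O)c1cc(Oc2ccc(NC(=O)c3cc4cccnc4n(-c4ccc(C(F)(F)F)cc4Cl)c3=O)cc2)ccn1` gives 4770 nM in this assay. Compound 4 `CCCNC(=O)c1cc(Oc2ccc(NC(=O)c3cc4cccnc4n(-c4ccc(C(F)(F)F)cc4Cl)c3=O)cc2)ccn1` has not yet been measured; it differs from compound 3 in one place: 2-chloro-4-(trifluoromethyl)phenyl in place of 4-chlorophenyl on an aromatic nitrogen. The same change has been measured once before, in a different setting of the chain: a 14-fold higher number from compound 1 to compound 2 (1.16 log units; beyond the scatter). That step bears directly on the present one, and a step of similar size in the same direction is therefore expected, a 14-fold higher number from compound 3 to compound 4 (1.15 log units; beyond the scatter). Compound 4 is accordingly expected to give about 5500 nM in this assay, with a range from 2000 nM to 15000 nM.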

Compound 4, half-maximal inhibitory concentration: 1960 nM
Compound 4: the middle estimate sits 2.8-fold (0.45 log units) above what was measured, outside the stated range (below it).
By their numbers in this assay, from the lowest: compounds 1 and 3 (each within the scatter of the next); then compound 4; then compound 2.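

In this assay, as far as these compounds go, the change to 2-chloro-4-(trifluoromethyl)phenyl on the aromatic nitrogen again gives weaker inhibition, with a 5.0-fold higher number from compound 3 to compound 4 (0.70 log units; beyond the scatter), so the direction holds on the propyl amide, but the size does not carry over from the ethyl amide: the same change on two cores in this assay, a 14-fold higher number (1.16 log units; beyond the scatter) from compound 1 to compound 2 and a 5.0-fold higher number (0.70 log units; beyond the scatter) from compound 3 to compound 4, 2.9-fold (0.46 log units) apart, beyond the scatter of two such steps The extra methyl on the chain, which made no clear difference with 4-chlorophenyl, does make one with the larger group, with a 2.4-fold lower number from compound 2 to compound 4 (0.39 log units; beyond the scatter), so the two places do not act independently: the same change on two cores in this assay, a 1.2-fold higher number (0.07 log units; within the scatter) from compound 1 to compound 3 and a 2.4-fold lower number (0.39 log units; beyond the scatter) from compound 2 to compound 4, 2.9-fold (0.46 log units) apart, beyond the scatter of two such steps Whether the chlorine or the trifluoromethyl of the entering group carries the loss stays open. So does how a butyl chain on the amide would behave with either group.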